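A few compounds are considered here, and "the series" means these few. Any claim that something is new, unique, unknown or untested is made for them only; others in the source may bear on it.

Measured so far in an ADME assay on HCT-116 cells (Homo sapiens) for antiproliferative activity; a higher number here means a weaker inhibitor, a lower number a stronger inhibitor:
compound 1 `COc1ccc(C(N)=O)cc1/C=C/c1ccc(Cl)cc1`: 7100 nM
compound 2 `COc1ccc(C(N)=O)cc1/C=C/c1ccc(C)cc1`: 48000 nM
compound 3 `COc1ccc(C(N)=O)cc1/C=C/c1cccc(C)c1`: 23000 nM

Compound 3 has the same atoms as compound 2, joined differently; the difference between the two cores is not broken down here. Compound 2 to compound 1 is one change: chloro in place of methyl on an aromatic carbon The step was a 6.8-fold lower number from compound 2 to compound 1 (0.83 log units; beyond the scatter).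

Compound 4 `COc1ccc(C(N)=O)cc1/C=C/c1cccc(Cl)c1` is not yet measured. From compound 3 it differs as follows: chloro in place of methyl on an aromatic carbon This is the same kind of change as that from compound 2 to compound 1, but not the same: there the place is para to a large group, here meta to a large group. The expectation for compound 4 rests on a 6.8-fold lower number from compound 2 to compound 1 (0.83 log units; beyond the scatter) and allows for the different place. For compound 4 the expected step is a 4.6-fold lower number from compound 3 to compound 4 (0.66 log units; beyond the scatter). Compound 4 is estimated at 5000 nM, within 2000 nM to 15000 nM.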

Compound 4, half-maximal inhibitory concentration: 15000 nM
Estimate against measurement, compound 4: 3.0-fold (0.48 log units) below, and the stated range covers the measured number.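

In this assay, chloro in place of methyl on an aromatic carbon, meta to a large group, gives a 1.5-fold lower number from compound 3 to compound 4 (0.19 log units; within the scatter), which leaves compound 3 and compound 4 level within the scatter. The size of this step does not carry unchanged from one core to the other: the same change on two cores in this assay, a 6.8-fold lower number (0.83 log units; beyond the scatter) from compound 2 to compound 1 and a 1.5-fold lower number (0.19 log units; within the scatter) from compound 3 to compound 4, 4.4-fold (0.64 log units) apart, beyond the scatter of two such steps. Going by these compounds alone, two pairs show only that the step depends on the core; they do not show what sets its size, nor how it would read on any further core.

Open, as far as these compounds go, is how an amine, a nitrile or a carboxylic acid would read in place of the chloro on either core. Also open, from the compounds shown here alone, is whether any of these would show the same dependence on the core.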